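The source may report more compounds than this note shows. Statements on the series, on what has been measured and on what is new or still open speak of the compounds shown alone.

In an ADME assay (liver) for metabolic stability, with Liver microsome (Homo sapiens) as the target, using microsomes (on this read-out lower numbers stand for a shorter-lived compound and higher numbers for a longer-lived compound), the half-life of compound 3 (`CCc1nc2cc(Cl)ccn2c1C(=O)NCc1ccc(-c2ccc(C)cc2)cc1`) is 0.423 h and lies within the usual scatter of two related compounds: compound 1 (`CCCc1nc2ccccn2c1C(=O)NCc1ccc(-c2ccccc2)cc1`) at 0.373 h and compound 2 (`CCc1nc2ccc(Cl)cn2c1C(=O)NCc1ccc(-c2ccc(C)cc2)cc1`) with 0.508 h as its reading. The next compound, compound 4 (`CCc1nc2cc(Cl)ccn2c1C(=O)NCc1ccc(-c2ccc[nH]2)cc1`), differs from compound 3 in one place (1H-pyrrol-2-yl in place of 4-methylphenyl on an aromatic carbon): 1H-pyrrol-2-yl in place of 4-methylphenyl on an aromatic carbon, para to a large group.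

Among the compounds with values here, none of the measured compounds carries 1H-pyrrol-2-yl, and no measured pair differs in only one place, so the data offer no direct precedent for this swap. What they do show is a narrow spread: compound 1 at 0.373 h and compound 2 at 0.508 h stay within the scatter of each other even though they differ in more than one place. Three compounds are thin evidence, however, and a new group could still bring a surprise. The expected step of a 1.2-fold lower number from compound 3 to compound 4 (0.07 log units; within the scatter) is small and no larger than the scatter, with a slight lean towards a lower number. For compound 4 the estimated half-life is 0.36 h with an expected range from 0.15 h to 0.8 h in repeat measurements.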

Compound 4, half-life: > 2 h
Compound 4 gave a limit, no number; the forecaster's own chance of this, stated with the estimate: 5%; middle value at least 5.5-fold (0.74 log units) from the limit.
By their numbers in this assay, from the lowest: compounds 1, 3 and 2 (each within the scatter of the next). At a limit, above all of these: compound 4.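

In this assay, within the data shown here, placing 1H-pyrrol-2-yl instead of 4-methylphenyl on this aromatic carbon, para to a large group, gives an at least 4.7-fold higher number from compound 3 to compound 4 (0.67 log units; beyond the scatter), and this is the first change in a single place that can be read. Among these compounds, it shows that the group at this position can move the half-life beyond the scatter, something the earlier compounds could not show, since they lie within the scatter of one another and differ in more than one place. Compound 4 reads > 2 h, which is a limit of the assay and not a number, so the full size of the change remains unknown: the limit of > 2 h in this assay, at which 1 of the 4 values shown sits.

The swap replaces a six-membered carbon ring with a five-membered aromatic ring and brings in a nitrogen with a hydrogen-bond donor all at once, and the compounds shown cannot separate these features. On these data alone, it also remains open whether a furan ring, or a pyrrole with a methyl group on its nitrogen, would give a similar half-life at this position.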